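Adding a second hydroxyethyl arm to compound 3

The source may hold more compounds than are shown below. What is called first, only, known or untested is meant among the compounds shown, and "the series" means these compounds.

Measured in a functional assay on SW-620 cells (Homo sapiens) for inhibition, read by MTT assay, with a stated time of 4 days (a higher number here means a weaker inhibitor, a lower number a stronger inhibitor), where each value is a limit and not a number:
- compound 1 `COc1cc(NC(C)CCCNC(=O)NNC(=O)NCCCCCO)c2ncccc2c1`: > 100000 nM
- compound 2 `COc1cc(NC(C)CCCNC(=O)NN)c2ncccc2c1`: > 100000 nM
- compound 3 `COc1cc(NC(C)CCCNC(=O)NNC(=O)NCCO)c2ncccc2c1`: > 100000 nM

Compound 3 offers no exact starting point, and its > 100000 nM is only a limit. It shares that position with the other two compounds, as the evidence shows: the limit of > 100000 nM in this assay, at which 3 of the 3 values shown sit.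

The next compound, compound 4 `COc1cc(NC(C)CCCNC(=O)NNC(=O)N(CCO)CCO)c2ncccc2c1`, carries one change from compound 3: 2-hydroxyethyl in place of hydrogen on an amide-type nitrogen. In short, 2-hydroxyethyl takes the place of hydrogen on an amide-type nitrogen.

Among the measured compounds shown here, three measured steps bear on this change: a step that the two limits leave unreadable from compound 1 to compound 2, a step that the two limits leave unreadable from compound 1 to compound 3 and a step that the two limits leave unreadable from compound 2 to compound 3. For the measured compounds named here, none of them gives a size, so no measured step points to a gain or a loss in this assay. The expected result is a number no higher from compound 3 to compound 4 (the limit leaves the size open), with no clear shift in either direction, and the assay will most likely report only a limit again.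

For compound 4 the estimated value is 100000 nM, with an expected range from 30000 nM to 300000 nM.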

Compound 4, half-maximal inhibitory concentration: > 100000 nM
Compound 4 ended at the assay's limit; the forecaster's own chance of this, stated with the estimate: 85%; the middle value lies on the limit itself.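

In this assay compound 4 gives > 100000 nM, which is a limit and not a number. Its steps from compound 1, compound 2 and compound 3 cannot be read. As far as these compounds go, whether the side chains of these four compounds differ at all in this assay stays open.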